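Compound 3 to compound 4: a side-chain exchange

The source may hold more compounds than are shown below. What is called first, only, known or untested is meant among the compounds shown, and "the series" means these compounds.

Of the compounds shown here, three with a shared core have been read in an ADME assay on BJ cells (Homo sapiens) for cytotoxicity, with a stated time of 72 h; on this read-out higher numbers stand for an effect only at larger amounts of compound and lower numbers for an effect already at smaller amounts. Compound 1 `Nc1nc(-c2ccccn2)nn1-c1ncnc2ccccc12` gives only a limit, > 50000 nM. Compound 2 `COc1cc2c(-n3nc(-c4ccccn4)nc3N)ncnc2cc1O` also gives only a limit, > 27000 nM. Compound 3 `COc1cc2ncnc(-n3nc(-c4ccccn4)nc3N)c2cc1OCCCN(C)C` likewise gives only a limit, > 25000 nM. Going by the values given here, none of the three has a numerical value, so compound 3 cannot be ranked against the other two and no step among them can be read.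

Compound 4 `COc1cc2ncnc(-n3nc(-c4ccccn4)nc3N)c2cc1OCCNC(=O)OC(C)(C)C` has not yet been measured. It differs from compound 3 in one place: (tert-butoxycarbonyl)amino in place of (dimethylamino)methyl on a saturated chain carbon, two bonds along the chain from an oxygen on an aromatic ring. Cut one bond further out, the same exchange reads 3-(dimethylamino)propoxy to 2-((tert-butoxycarbonyl)amino)ethoxy.

No step beyond the scatter is expected in this assay, and neither direction is favoured. This expectation rests on compound 3, whose reading is the limit > 25000 nM, and on the absence of any numerical value in the set. The estimated change is a step that the limit leaves unreadable from compound 3 to compound 4, and it is expected to stay within the scatter. Compound 4 is expected at 30000 nM, with an estimated range of 12000 nM to 50000 nM.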

Compound 4, half-maximal effective concentration: > 15000 nM
Compound 4 ended at the assay's limit; the forecaster's own chance of this, stated with the estimate: 75%; the middle value does not contradict the limit.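

In this assay compound 4 gives > 15000 nM, which is a limit and not a number. Going by these compounds alone, compound 3 also reads only as a limit, and no step between compound 3 and compound 4 can be read. None of the four compounds shown gives a numerical value in this assay, which leaves open whether (tert-butoxycarbonyl)amino in place of (dimethylamino)methyl shifts the read-out at all.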